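Ring amine cap: acetyl to methylsulfonyl

This account rests on a few compounds, and the source may have more. Where it says the series, first, only, none or still open, it means among the compounds named here.

In a functional assay on HCT-116 cells (Homo sapiens) for antiproliferative activity, read by sulforhodamine B assay, with a stated time of 72 h (a higher number here means a weaker inhibitor, a lower number a stronger inhibitor), compound 1 (`COc1ncc(-c2ccc3ncc(NCc4ccccc4)c(OC)c3c2)cc1NS(=O)(=O)c1ccc(F)cc1F`) gives 16800 nM and compound 2 (`COc1ccc(CNc2cnc3ccc(-c4cnc(OC)c(NS(=O)(=O)c5ccc(F)cc5F)c4)cc3c2OC)cc1`) gives 10200 nM while compound 3 (`COc1ncc(-c2ccc3ncc(NCC4CCN(C(C)=O)CC4)c(OC)c3c2)cc1NS(=O)(=O)c1ccc(F)cc1F`) gives 1930 nM as the lowest of the three numbers. Compound 4 (`COc1ncc(-c2ccc3ncc(NCC4CCN(S(C)(=O)=O)CC4)c(OC)c3c2)cc1NS(=O)(=O)c1ccc(F)cc1F`) is not yet measured. It carries methylsulfonyl in place of acetyl on an amine nitrogen in a ring.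

Among the measured compounds shown here, no measured step changes this group directly. The closest evidence comes from an 8.7-fold lower number from compound 1 to compound 3 (0.94 log units; beyond the scatter) and a 5.3-fold lower number from compound 2 to compound 3 (0.72 log units; beyond the scatter) in which 1-acetylpiperidin-4-yl replaces an aromatic group on the same saturated chain carbon. Both steps are modest and beyond the scatter, but neither compares acetyl with methylsulfonyl. The remaining step, a 1.6-fold lower number from compound 1 to compound 2 (0.22 log units; within the scatter) within the scatter, concerns a different place on the molecule and offers no guidance here.

The data therefore give no basis for a direction, and no step beyond the scatter is expected in this assay for this exchange. For the measured compounds named here, the expectation stays anchored on compound 3 at 1930 nM as the only measured compound with a substituted ring amine. The estimated change is a 1.0-fold higher number from compound 3 to compound 4 (0.02 log units; within the scatter) with wide uncertainty. Compound 4 is expected at 2000 nM (estimated range 700 nM to 5500 nM).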

Compound 4, half-maximal inhibitory concentration: 1360 nM
The estimate for compound 4 lay 1.5-fold (0.17 log units) above the measured number; the range from low to high includes it.
By their numbers in this assay, from the lowest: compounds 4 and 3 (each within the scatter of the next); then compounds 2 and 1 (each within the scatter of the next).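

Methylsulfonyl in place of acetyl on the amine nitrogen in the ring, read in this assay, gives a 1.4-fold lower number from compound 3 to compound 4 (0.15 log units; within the scatter), so this position accepts either cap and the assay does not separate them. The lower numbers seen with the acetyl cap are therefore not confined to that group: the 1-(methylsulfonyl)piperidin-4-yl compound also shows a 7.5-fold lower number from compound 2 to compound 4 (0.88 log units; beyond the scatter) and a 12-fold lower number from compound 1 to compound 4 (1.09 log units; beyond the scatter), both in the same direction as the steps from these aromatic compounds to compound 3. No measurement on hand accounts for these steps or for the closeness of the two caps.

Still open, as far as these compounds go, is whether a free ring amine, with hydrogen on the nitrogen, or a phenylsulfonyl cap would stay at the level of compound 3 and compound 4. Also open, from the compounds shown here alone, is how much of the step from the aromatic groups belongs to the six-membered ring and how much to its cap, a question that a plain cyclohexyl group on the same chain carbon would address.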